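Three Aryl Acids at the Limit and a Fourth Isomer

This account rests on a few compounds, and the source may have more. Where it says the series, first, only, none or still open, it means among the compounds named here.

Compound 1 `COc1cccc(/C(=C\c2cn(C(C)=O)c3ccc(OCc4ccccc4)cc23)C(=O)O)c1` gives in a functional assay on KB cells (Homo sapiens) for cytotoxicity, read by MTT assay, with a stated time of 72 h (a lower number here means a stronger inhibitor, a higher number a weaker inhibitor), only the limit > 100000 nM, not a number.
Compound 2 `COc1cc(/C(=C\c2cn(C(C)=O)c3ccc(OCc4ccccc4)cc23)C(=O)O)cc(OC)c1OC` likewise reaches only the limit > 100000 nM in this assay.
Compound 3 `COc1ccc(OC)c(/C(=C\c2cn(C(C)=O)c3ccc(OCc4ccccc4)cc23)C(=O)O)c1` also stops at the limit > 100000 nM in this assay.

Compound 3 therefore stands where every measured compound stands: at the limit of this assay, with no number behind it. The three comparisons between the measured compounds, a step that the two limits leave unreadable from compound 1 to compound 2, a step that the two limits leave unreadable from compound 1 to compound 3 and a step that the two limits leave unreadable from compound 2 to compound 3, are all unreadable because of the limit of > 100000 nM in this assay, at which 3 of the 3 values shown sit. Nothing among them shows a step in either direction.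

Compound 4 `COc1ccc(/C(=C\c2cn(C(C)=O)c3ccc(OCc4ccccc4)cc23)C(=O)O)cc1OC` is a rearranged version of compound 3: 3,4-dimethoxyphenyl in place of 2,5-dimethoxyphenyl on a double-bonded chain carbon bound to a carbonyl carbon and a double-bonded chain carbon. Among the measured compounds shown here, the steps that bear on this change are the three above, and each of them is of unreadable size, since none of the compounds moved off the limit. For the measured compounds named here, there is thus no measured step pointing to a gain or a loss in this assay.

The expectation is that the change from compound 3 to compound 4, a step that the limit leaves unreadable from compound 3 to compound 4, produces no readable step in this assay. Compound 4 is estimated at 150000 nM in this assay, with a range from 40000 nM to 600000 nM, most likely again reported only as a limit.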

Compound 4, half-maximal inhibitory concentration: 96700 nM
Compound 4: middle estimate off by 1.6-fold (0.19 log units), on the high side, and the stated range covers the measured number.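

In this assay compound 4 gives 96700 nM, the only actual number in this small series, so 3,4-dimethoxyphenyl on this double-bonded chain carbon is the one aryl group shown that brings a reading inside the measurable range. The steps that result are an at least 1.0-fold lower number from compound 3 to compound 4 (0.01 log units; that floor lies within the scatter), an at least 1.0-fold lower number from compound 2 to compound 4 (0.01 log units; that floor lies within the scatter) and an at least 1.0-fold lower number from compound 1 to compound 4 (0.01 log units; that floor lies within the scatter), and each is only a floor that lies within the scatter, so this number cannot be called a real gain over the other three compounds. The true size of these steps stays unknown, and the steps among compound 1, compound 2 and compound 3 stay unreadable, because those three compounds give no number, only a limit: the limit of > 100000 nM in this assay, at which 3 of the 4 values shown sit.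

The compounds shown leave open whether any aryl group at this place can bring the number clearly down, for instance a hydroxy or an amine on the aromatic ring in place of a methoxy. They also leave open what a methyl ester or a primary amide in place of the carboxylic acid would do in this assay.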